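Aryl variation on a shared core in a cell assay

The source may report more compounds than this note shows. Statements on the series, on what has been measured and on what is new or still open speak of the compounds shown alone.

Measured so far:
compound 1 `CN(C)CCn1cnnc1-c1cc(Oc2ccc(NC(=O)N/N=C/c3c(Cl)cccc3Cl)cc2F)ccn1`: 1410 nM
compound 2 `CN(C)CCn1cnnc1-c1cc(Oc2ccc(NC(=O)N/N=C/c3cc(C(C)(C)C)cc(C(C)(C)C)c3O)cc2F)ccn1`: 980 nM

In a functional assay on A549 cells (Homo sapiens) for cytotoxicity, read by MTT assay, with a stated time of 72 h (on this read-out lower numbers stand for stronger inhibition and higher numbers for weaker inhibition), compound 1 gives 1410 nM, the highest of the two numbers at hand, while compound 2 gives 980 nM, and the two lie within the scatter of each other. Compound 3 `COc1ccc(OC)c(/C=N/NC(=O)Nc2ccc(Oc3ccnc(-c4nncn4CCN(C)C)c3)c(F)c2)c1` differs from compound 1 by 2,5-dimethoxyphenyl in place of 2,6-dichlorophenyl on a carbon with a double bond to nitrogen. Within the data shown here, no measured pair isolates this change, so nothing beyond the scatter is expected in either direction; the estimated step of a 1.1-fold higher number from compound 1 to compound 3 (0.03 log units; within the scatter) is taken as close to none. Compound 3 is expected near 1500 nM in this assay, in a range from 600 nM to 4000 nM.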

Compound 3, half-maximal inhibitory concentration: 1950 nM
Estimate against measurement, compound 3: 1.3-fold (0.11 log units) below; the measured number falls inside the stated range.
By their numbers in this assay, from the lowest: compounds 2, 1 and 3 (each within the scatter of the next).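

In this assay the aryl group on the carbon with a double bond to nitrogen changes from 2,6-dichlorophenyl to 2,5-dimethoxyphenyl with a 1.4-fold higher number from compound 1 to compound 3 (0.14 log units; within the scatter) as the step, so this exchange of substituents on the phenyl ring gives no shift beyond the scatter. Nothing on hand explains the size of this step.

Open, from the compounds shown here alone, is whether any group at this position moves the number beyond the scatter, such as a phenyl ring carrying an amine or a carboxylic acid, or a cyclohexyl group in place of the aromatic ring.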